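The compounds below may be only part of what the source reports. "The series", "measured", "known", "first", "only" and "open" are said of these compounds alone.

Series notes. Among the compounds with values here, in an assay on LM cells for displacement of a labelled ligand from Neuropeptide Y receptor type 5 (Homo sapiens) (a lower number here means a stronger inhibitor, a higher number a weaker inhibitor), compound 1 `Fc1ccc(C2(c3ccc(F)cc3)CNC(c3cccc(Cl)c3)=N2)cc1` gives 5.4 nM and holds the second highest of the three numbers known; compound 2 `Fc1ccc(C2(c3ccc(F)cc3)CNC(c3cccc(C(F)(F)F)c3)=N2)cc1` is nearest with 6.2 nM, compound 3 `N#Cc1cccc(C2=NC(c3ccc(F)cc3)(c3ccc(F)cc3)CN2)c1` furthest with 2.7 nM. Every measured step swaps the group on the same aromatic carbon: a 1.1-fold higher number from compound 1 to compound 2 (0.06 log units; within the scatter), a 2.0-fold lower number from compound 1 to compound 3 (0.30 log units; within the scatter) and a 2.3-fold lower number from compound 2 to compound 3 (0.36 log units; beyond the scatter). Compound 4 `O=Cc1cccc(C2=NC(c3ccc(F)cc3)(c3ccc(F)cc3)CN2)c1` differs from compound 1 thus: formyl in place of chloro on an aromatic carbon. Formyl, like cyano, enters as a hydrogen-bond acceptor where chloro carried none, and the closest precedent is compound 3 with a 2.0-fold lower number from compound 1 to compound 3 (0.30 log units; within the scatter); only a small downward step in this assay, if any beyond the scatter, is expected. Compound 4 is therefore expected near 4.5 nM, between 2 nM and 12 nM, which amounts to a 1.2-fold lower number from compound 1 to compound 4 (0.08 log units; within the scatter).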

Compound 4, half-maximal inhibitory concentration: 8.7 nM
Compound 4: the middle estimate sits 1.9-fold (0.29 log units) below what was measured; low and high end bracket the measured number.
By their numbers in this assay, from the lowest: compounds 3, 1, 2 and 4 (each within the scatter of the next, the first and the last beyond it).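

In this assay, formyl on this aromatic carbon stays within the scatter of chloro (a 1.6-fold higher number from compound 1 to compound 4 (0.21 log units; within the scatter)) and of trifluoromethyl (a 1.4-fold higher number from compound 2 to compound 4 (0.15 log units; within the scatter)). Only cyano separates from it (a 3.2-fold higher number from compound 3 to compound 4 (0.51 log units; beyond the scatter)), so a hydrogen-bond acceptor entering here does not by itself reproduce the number of compound 3. Nothing at hand accounts for this gap between formyl and cyano. Open, from the compounds shown here alone, is where an amine, a carboxylic acid or an acetyl group on this carbon would fall relative to cyano and formyl.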